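This account rests on a few compounds, and the source may have more. Where it says the series, first, only, none or still open, it means among the compounds named here.

Measured compounds:
compound 1 `NNc1cc(-c2c(-c3ccc(F)cc3)nn3c(NC4CCCC4)cccc23)ccn1` – 40000 nM
compound 2 `Fc1ccc(-c2nn3c(NC4CCCC4)cccc3c2-c2cccnc2NC2CCCC2)cc1` – "not determined" (no result reported)
compound 3 `Fc1ccc(-c2nn3c(NC4CCCC4)cccc3c2-c2ccnc(NC3CCCC3)c2)cc1` – > 40000 nM

For the measured compounds named here, in an ADME assay on Vero cells (Chlorocebus sabaeus) for cytotoxicity (a lower number here means that less compound is tolerated, a higher number that more compound is tolerated), compound 1 gives 40000 nM, the only plain number in the set. Compound 2 has no result in this assay. For compound 3 the entry > 40000 nM is a limit of this assay and not a number; the evidence of the measured series is the limit of > 40000 nM in this assay, at which 1 of the 3 values shown sits. Going by the values given here, the one step that can be read, a number no lower from compound 1 to compound 3 (the limit leaves the size open), therefore leaves its size open.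

Compound 4 `Fc1ccc(-c2nn3c(NC4CCCC4)cccc3c2-c2cn[nH]c2)cc1` has not yet been measured in this assay. It differs from compound 1 by 1H-pyrazol-4-yl in place of 2-(aminoamino)pyridin-4-yl on an aromatic carbon. Among the compounds with values here, no measured pair shares this exact change; the nearest comparison is compound 1 to compound 3, where the group on the pyridine ring was altered and the readout stayed at or beyond the value of compound 1. Given that a smaller change in the same region produced no downward movement, the step from compound 1 to compound 4 is expected to stay within the scatter or go upward, giving an expected no change at the digits printed from compound 1 to compound 4 (within the scatter). Compound 4 is accordingly estimated at 40000 nM, within 15000 nM to 80000 nM, with a real chance that only a limit is reported.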

Compound 4, half-maximal cytotoxic concentration: 10000 nM
Compound 4: middle estimate off by 4.0-fold (0.60 log units), on the high side; measured number outside the range, below it.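

In this assay the series now holds a step of readable size at this place on the core: a 4.0-fold lower number from compound 1 to compound 4 (0.60 log units; beyond the scatter). The earlier change, cyclopentyl for amino on the nitrogen carried by the pyridine ring, showed no downward movement, and its size could not be read, whereas replacing the whole 2-(aminoamino)pyridin-4-yl group with 1H-pyrazol-4-yl shows that the number at this place can fall. This exchange alters several things at once, the ring size, the number of hetero atoms, the heavy atoms, and the hydrogen-bond donors and acceptors, so this single step cannot assign the fall to any one of them.

How much room the series has at the top of the range remains unresolved: the limit of > 40000 nM in this assay, at which 1 of the 4 values shown sits. Whether a plain phenyl ring, a pyrazole with a methyl group on its nitrogen or a pyridine with a simple amine would fall with compound 4 or stay with compound 1 is left open, so the ring exchange and the loss of the aminoamino group cannot yet be told apart.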